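This account rests on a few compounds, and the source may have more. Where it says the series, first, only, none or still open, it means among the compounds named here.

Compounds measured so far, with their solubility values:

Compound 1, `Cc1cc(NCc2ccccn2)n2ncc(-c3ccc(F)c(Cl)c3)c2n1`. In a physicochemical assay for solubility, read by HPLC, using the shake flask method, measured as kinetic solubility, with a stated time of 2 h, at pH 7.4 (on this read-out higher numbers stand for higher solubility and lower numbers for lower solubility), compound 1 gives < 5000 nM, which is a limit of the assay rather than a number.
Compound 2, `Cc1cc(NCc2ccccn2)n2ncc(-c3ccccc3C)c2n1`. In this assay compound 2 gives < 5000 nM, again a limit.
Compound 3, `Cc1cc(NCc2ccccn2)n2ncc(-c3c(C)cccc3C)c2n1`. In this assay compound 3 gives < 5000 nM, also a limit.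

Compound 3 therefore stands at the limit of < 5000 nM in this assay, at which 3 of the 3 values shown sit, together with the two other compounds, so no one of the three can be placed above or below another. The steps between them, a step that the two limits leave unreadable from compound 1 to compound 2, a step that the two limits leave unreadable from compound 1 to compound 3 and a step that the two limits leave unreadable from compound 2 to compound 3, are all unreadable for the same reason: both ends of each step are limits.

The next compound, compound 4, `Cc1cc(NCc2ccccn2)n2ncc(-c3cccc(N)c3)c2n1`, differs from compound 3 by 3-aminophenyl in place of 2,6-dimethylphenyl on an aromatic carbon. Within the data shown here, none of the measured steps gives a readable size, so none of them tells how large the step into compound 4 should be, or in which direction. Among the measured compounds shown here, the only guide is that every compound measured so far, including compound 3 with < 5000 nM, sits at the limit.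

On that basis compound 4 is expected to give about 6000 nM in this assay, within a range of 1500 nM to 40000 nM, meaning an estimated step of an at least 1.2-fold higher number from compound 3 to compound 4 (0.07 log units; that floor lies within the scatter) from compound 3, with a fair chance that only a limit is reported again.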

Compound 4, solubility: 160000 nM
Beside the measured number, compound 4's estimate is 27-fold (1.43 log units) below it, outside the stated range (above it).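

The steps among compound 1, compound 2 and compound 3 cannot be read, so those compounds could not show whether the group on this aromatic carbon of the five-membered aromatic ring matters in this assay. Placing 3-aminophenyl there shows that it can matter, giving an at least 32-fold higher number from compound 3 to compound 4 (1.50 log units; beyond the scatter), an at least 32-fold higher number from compound 2 to compound 4 (1.50 log units; beyond the scatter) and an at least 32-fold higher number from compound 1 to compound 4 (1.50 log units; beyond the scatter). Unlike 2,6-dimethylphenyl, which has no hydrogen-bond donor or acceptor, 3-aminophenyl brings one of each, and compound 4 alone is off the limit: the limit of < 5000 nM in this assay, at which 3 of the 4 values shown sit.

The compounds shown leave open whether the gain goes with the amine itself or with the loss of the groups it replaces, since 3-aminophenyl differs from each of the other groups in more than one feature. On these data alone, a plain phenyl group, or a hydroxyl or carboxylic acid on the ring in place of the amine, would help to separate these possibilities, and how far the read-out can rise at this position also remains unknown.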